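The compounds below may be only part of what the source reports. "The series", "measured", "known", "first", "only" and "open" are said of these compounds alone.

Compound 1 `Nc1scc(CN2CCN(c3cccc(C(F)(F)F)c3)CC2)c1C(=O)c1ccc(Cl)cc1` and compound 2 `Nc1scc(CN2CCN(c3ccc(OC(F)(F)F)cc3)CC2)c1C(=O)c1ccc(Cl)cc1` share one core and differ only in the aryl group on an amine nitrogen in a ring. In a functional assay on CHO cells with adenosine receptor A1 (Homo sapiens) as the target, read by cAMP accumulation and immunoassay, with a stated time of 6 min, tested at 0.1 uM (a higher number here means a weaker effect of the compound at the concentration tested, a lower number a stronger effect), compound 1 gives -30%. In this assay compound 2 gives -13%, the highest of the two numbers recorded, and the step of a number 17 percentage points higher from compound 1 to compound 2 (beyond the scatter) is modest yet beyond the scatter. Compound 3 `Nc1scc(CN2CCN(c3ccc(F)cc3F)CC2)c1C(=O)c1ccc(Cl)cc1` carries 2,4-difluorophenyl in place of 4-(trifluoromethoxy)phenyl on an amine nitrogen in a ring. For the measured compounds named here, no measured step exchanges one fluorinated aryl group for another of this kind, so the only step that bears on the change is a number 17 percentage points higher from compound 1 to compound 2 (beyond the scatter), and it shows that swapping the aryl group at this position moves the read-out by a modest amount. Going by the values given here, because compound 2 stands at -13% and the one known step is only modest, the account expects for compound 3 a step of a number 5 percentage points lower from compound 2 to compound 3 (within the scatter) that does not clearly leave the scatter, with a slight lean toward a lower number. Compound 3 is therefore estimated at -18%, with a range from -42% to 6%.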

Compound 3, a percentage reported as activity, at one concentration (the size of the read-out at that concentration, not a potency): -17%
The estimate for compound 3 lay 1 percentage points below the measured number, within the range that was stated.
By their numbers in this assay, from the lowest: compound 1; then compounds 3 and 2 (each within the scatter of the next).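

In this assay, the step of a number 4 percentage points lower from compound 2 to compound 3 (within the scatter) shows that the read-out does not separate 2,4-difluorophenyl from 4-(trifluoromethoxy)phenyl on the amine nitrogen in the ring, even though the entering group has fewer heavy atoms and lacks the oxygen and the hydrogen-bond acceptor of the group it replaces. For the compounds shown here, the step of a number 13 percentage points higher from compound 1 to compound 3 (beyond the scatter) is a second change away from 3-(trifluoromethyl)phenyl that leaves the scatter, so compound 1 now stands apart from two different aryl groups, where the earlier compounds offered only one such comparison. Nothing available here accounts for this separation of compound 1 from the other two compounds.

The three compounds do not tell whether the separation of compound 1 follows from the trifluoromethyl group itself or from where it sits on the phenyl ring, since no two of them carry the same group at different places. On these data alone, all three aryl groups also carry fluorine, so the read-out with an unsubstituted phenyl, or with a phenyl bearing a methoxy group or a nitrile, remains open.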